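Urea for a branched alkyl amide on a shared core

The source may hold more compounds than are shown below. What is called first, only, known or untested is meant among the compounds shown, and "the series" means these compounds.

Measured so far in a functional assay on WI-38 VA13 cells (Homo sapiens) for cytotoxicity; a lower number here means that less compound is needed, a higher number that more compound is needed for the effect:
- compound 1, `COc1ccc(C(=O)Nc2ccc3nc(NC(=O)C4CCCCC4)sc3c2)cc1`: 4.9 ug/mL
- compound 2, `O=C(Nc1ccc2nc(NC(=O)C3CCCCC3)sc2c1)c1ccc(Cl)cc1Cl`: a limit, > 4 ug/mL
- compound 3, `CCC(C)(C)C(=O)Nc1ccc2nc(NC(=O)C3CCCCC3)sc2c1`: 1 ug/mL

The three compounds share one core and differ only in the group on a carbonyl carbon. Compound 3 shows the lowest number of the two that were read as numbers; compound 1 sits higher, with a 4.9-fold lower number from compound 1 to compound 3 (0.69 log units; beyond the scatter) separating them. For compound 2 this assay gave only a limit (the limit of > 4 ug/mL in this assay, at which 1 of the 3 values shown sits), so the size of a step that the limit leaves unreadable from compound 1 to compound 2 cannot be read. Still, an at least 4.0-fold lower number from compound 2 to compound 3 (0.60 log units; beyond the scatter) shows that moving from an aromatic group to the branched alkyl lowered the number.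

Compound 4, `Cc1cccc(C)c1NC(=O)Nc1ccc2nc(NC(=O)C3CCCCC3)sc2c1`, has not yet been measured. Its change from compound 3 is (2,6-dimethylphenyl)amino in place of 1,1-dimethylpropyl on a carbonyl carbon. Both measured steps that bear on it, a 4.9-fold lower number from compound 1 to compound 3 (0.69 log units; beyond the scatter) and an at least 4.0-fold lower number from compound 2 to compound 3 (0.60 log units; beyond the scatter), run from an aromatic group to the alkyl and lower the number; compound 4 goes the other way, back to an aromatic group, now attached through an amino link. A higher number than for compound 3 is therefore expected, of about a 4.0-fold higher number from compound 3 to compound 4 (0.60 log units; beyond the scatter). For compound 4 the estimate in this assay is 4 ug/mL, between 1.5 ug/mL and 10 ug/mL, with a real chance that only a limit is reported, as happened for compound 2.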

Compound 4, half-maximal effective concentration: 0.56 ug/mL
The estimate for compound 4 lay 7.1-fold (0.85 log units) above the measured number; the whole stated range lies above it.
By their numbers in this assay, from the lowest: compounds 4 and 3 (each within the scatter of the next); then compound 1.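

In this assay, the urea compound 4 and the branched alkyl amide compound 3 cannot be told apart, with a 1.8-fold lower number from compound 3 to compound 4 (0.25 log units; within the scatter). An aromatic ring in this group therefore does not always go with a higher number, as the (2,6-dimethylphenyl)amino group shows an 8.8-fold lower number from compound 1 to compound 4 (0.94 log units; beyond the scatter) and an at least 7.1-fold lower number from compound 2 to compound 4 (0.85 log units; beyond the scatter). That second step rests on the value for compound 2, which is only a limit: the limit of > 4 ug/mL in this assay, at which 1 of the 4 values shown sits.

The compounds shown leave open whether the amino link, the two methyl groups on the ring, or both separate compound 4 from compound 1 and compound 2, which carry their rings directly on the carbonyl carbon. A plain phenylamino group and a 2,6-dimethylphenyl group set directly on the carbonyl carbon would pull these two features apart.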